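A few compounds are considered here, and "the series" means these few. Any claim that something is new, unique, unknown or untested is made for them only; others in the source may bear on it.

Measured compounds:
compound 1, `Clc1ccc(C2CC(c3ccccc3)=NN2c2ccc(-c3ccccc3)nn2)cc1` — 100000 nM
compound 2, `Clc1ccc(C2=NN(c3ccc(-c4ccccc4)nn3)C(c3ccccc3)C2)cc1` — 10000 nM

In a functional assay on MCF7 cells (Homo sapiens) for antiproliferative activity, read by MTT assay, with a stated time of 24 h (on this read-out higher numbers stand for weaker inhibition and lower numbers for stronger inhibition), compound 2 gives 10000 nM, the lowest of the two numbers. Compound 1 gives 100000 nM, a higher number that lies beyond the scatter. Compound 3, `Clc1ccc(C2=NN(c3ccc(-c4ccccc4)nn3)C(c3ccc(Cl)cc3)C2)cc1`, differs from compound 2 by chloro in place of hydrogen on an aromatic carbon, phenyl becoming 4-chlorophenyl. Among the measured compounds shown here, no measured pair shows this change, so its size is untested here. Compound 3 is expected to give 7000 nM, with a range from 2500 nM to 20000 nM. The expected step of a 1.4-fold lower number from compound 2 to compound 3 (0.15 log units; within the scatter) is small, within the scatter or slightly toward a lower number.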

Compound 3, half-maximal inhibitory concentration: 8800 nM
The estimate for compound 3 lay 1.3-fold (0.10 log units) below the measured number, and the stated range covers the measured number.
By their numbers in this assay, from the lowest: compounds 3 and 2 (each within the scatter of the next); then compound 1.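

In this assay, chloro in place of hydrogen on the phenyl of compound 2 moves the number only within the scatter (a 1.1-fold lower number from compound 2 to compound 3 (0.06 log units; within the scatter)), whereas the same kind of change on the phenyl of compound 1 gives a large step beyond the scatter (an 11-fold lower number from compound 1 to compound 3 (1.06 log units; beyond the scatter)). Phenyl to 4-chlorophenyl therefore counts for much on one phenyl and for little on the other, which neither earlier compound could show. Nothing measured here gives a reason for this contrast.

The compounds shown leave open whether an amine or a methoxy group at this place would behave as chloro does.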